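A few compounds are considered here, and "the series" means these few. Any claim that something is new, unique, unknown or untested is made for them only; others in the source may bear on it.

Compound 1 `CCOC(=O)c1cc(-c2cccc(OCc3cccc(C(F)(F)F)c3)c2)on1` and compound 2 `CCOC(=O)c1cc(-c2cccc(OCc3cccc(Cl)c3)c2)on1` share one core and differ in a single group. In an ADME assay on Vero cells (Chlorocebus sabaeus) for cytotoxicity, with a stated time of 72 h (a higher number here means a weaker inhibitor, a lower number a stronger inhibitor), compound 1 gives only a limit, > 128000 nM. In this assay compound 2 also gives only a limit, > 128000 nM. Both readings sit at the limit of > 128000 nM in this assay, at which 2 of the 2 values shown sit, so the step that the two limits leave unreadable from compound 1 to compound 2 cannot be sized. Compound 3 `CCOC(=O)c1cc(-c2cccc(OCc3cccc([N+](=O)[O-])c3)c2)on1` follows from compound 2 through (nitro in place of chloro on an aromatic carbon). With no readable step to build on, no change beyond the scatter is expected. Compound 3 is estimated at 200000 nM in this assay, between 100000 nM and 500000 nM. The expected step is a step that the limit leaves unreadable from compound 2 to compound 3.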

Compound 3, half-maximal inhibitory concentration: > 128000 nM
Compound 3: a limit, no number; the forecaster's own chance of this, stated with the estimate: 85%; the middle value lies beyond the limit too.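

Within the data shown here, compound 3, like compound 1 and compound 2, gives only a limit in this assay, so no step among the three can be read: the limit of > 128000 nM in this assay, at which 3 of the 3 values shown sit. Still open, from the compounds shown here alone, is where the true values of these three compounds lie and whether trifluoromethyl, chloro and nitro differ at all in this assay.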